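Shorter Linker and a Thiadiazole Ring in Place of Benzoxazole

The source may hold more compounds than are shown below. What is called first, only, known or untested is meant among the compounds shown, and "the series" means these compounds.

Compound 2 `COc1ccc(CN(C(=O)CCSc2nc3ccccc3o2)c2cc(OC)c(OC)c(OC)c2)cc1` gives 20200 nM in a functional assay on PC-3 cells (Homo sapiens) for antiproliferative activity, read by MTT assay, with a stated time of 48 h (on this read-out lower numbers stand for stronger inhibition and higher numbers for weaker inhibition), level with compound 1 `COc1ccc(CN(C(=O)CSc2nc3ccc(OC)cc3s2)c2cc(OC)c(OC)c(OC)c2)cc1`, which gives 20200 nM; together they hold the lowest numbers of the three, while compound 3 `COc1ccc(CN(C(=O)CCCCSc2nc3ccccc3o2)c2cc(OC)c(OC)c(OC)c2)cc1` gives 45600 nM. Compound 4 `COc1ccc(CN(C(=O)CSc2nncs2)c2cc(OC)c(OC)c(OC)c2)cc1` differs from compound 2 by (1,3,4-thiadiazol-2-yl)sulfanyl in place of ((1,3-benzoxazol-2-yl)sulfanyl)methyl on a saturated chain carbon bound to a carbonyl carbon. Going by the values given here, two steps bear on this: the ring swap no change at the digits printed from compound 1 to compound 2 (within the scatter), and the chain lengthening a 2.3-fold higher number from compound 2 to compound 3 (0.35 log units; beyond the scatter). Since a ring exchange left the number unchanged and lengthening the chain raised it modestly, shortening the chain with another ring is expected to give no step beyond the scatter, a 1.0-fold lower number from compound 2 to compound 4 (0.00 log units; within the scatter). Compound 4 is therefore estimated at 20000 nM, within 8000 nM to 50000 nM.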

Compound 4, half-maximal inhibitory concentration: 5530 nM
For compound 4 the middle estimate is 3.6-fold (0.56 log units) above the measured one, outside the stated range (below it).
By their numbers in this assay, from the lowest: compound 4; then compounds 1 and 2 (each within the scatter of the next); then compound 3.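

Going by these compounds alone, exchanging the group on the sulfur produced the first step here toward lower numbers beyond the scatter: 1,3,4-thiadiazol-2-yl in place of 6-methoxy-1,3-benzothiazol-2-yl gives a 3.7-fold lower number from compound 1 to compound 4 (0.56 log units; beyond the scatter), and (1,3,4-thiadiazol-2-yl)sulfanyl in place of ((1,3-benzoxazol-2-yl)sulfanyl)methyl gives a 3.7-fold lower number from compound 2 to compound 4 (0.56 log units; beyond the scatter). Within the data shown here, this position therefore responds to the group it carries, which the earlier compounds did not show. Nothing available explains the gain.

The second step changes chain and ring together, and the compounds shown do not separate the two. From the compounds shown here alone, whether an amine or a carboxylic acid on the 1,3,4-thiadiazol-2-yl ring would lower the number further remains open.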